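The source may report more compounds than this note shows. Statements on the series, on what has been measured and on what is new or still open speak of the compounds shown alone.

Measured compounds in a functional assay on MCF7 cells (Homo sapiens) for cytotoxicity, read by MTT assay, with a stated time of 48 h; on this read-out higher numbers stand for weaker inhibition and lower numbers for stronger inhibition:
compound 1, `Fc1ccc(Nc2nc(-c3cccc(F)c3)nc3ccc(F)cc23)cc1`, gives > 50000 nM, a limit of the assay.
compound 2, `Fc1cccc(-c2nc(Nc3ccccc3F)c3cc(F)ccc3n2)c1`, gives > 50000 nM, a limit of the assay.
compound 3, `Fc1cccc(-c2nc(Nc3cccc(Cl)c3)c3cc(F)ccc3n2)c1`, gives > 50000 nM, a limit of the assay.

Within the data shown here, compound 3 stands only at a limit in this assay, and the two further values shown are limits as well, so no compound of the series has a number. The steps among the measured compounds, a step that the two limits leave unreadable from compound 1 to compound 2, a step that the two limits leave unreadable from compound 1 to compound 3 and a step that the two limits leave unreadable from compound 2 to compound 3, all change the aryl group on the nitrogen, yet none can be read in size: every value sits at the limit of > 50000 nM in this assay, at which 3 of the 3 values shown sit.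

Compound 4, `Fc1cccc(-c2nc(Nc3cccc(Br)c3)c3cc(F)ccc3n2)c1`, differs from compound 3 by bromo in place of chloro on an aromatic carbon. The measured steps touch the same aryl group on the nitrogen, but as all three are unreadable they give no size for a halogen exchange, and nothing shown suggests that compound 4 would move off the limit. No step beyond the scatter is expected; the step expected from compound 3 to compound 4 is a step that the limit leaves unreadable from compound 3 to compound 4. Compound 4 is therefore estimated at 80000 nM, in the range 30000 nM to 300000 nM, and is most likely to be reported once more only as a limit.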

Compound 4, half-maximal inhibitory concentration: > 50000 nM
Compound 4: no number, only a limit; the forecaster's own chance of this, stated with the estimate: 85%; the middle value does not contradict the limit.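

In this assay compound 4 gives > 50000 nM, a limit and not a number. Among these compounds, no step from compound 1, compound 2 or compound 3 to compound 4 can be read, because all four compounds stand at a limit: the limit of > 50000 nM in this assay, at which 4 of the 4 values shown sit. The compounds shown leave open whether any aryl group on the nitrogen moves a compound off this limit.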